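This account rests on a few compounds, and the source may have more. Where it says the series, first, only, none or still open, it means among the compounds named here.

Working notes on the series.

Three compounds of this set share one core and have been run in a toxicity assay on the whole organism (J774 cells) for cytotoxicity, with Mus musculus as the target, read by MTT assay, with a stated time of 24 h, tested at 30 uM; on this read-out higher numbers stand for a weaker effect at the one concentration tested and lower numbers for a stronger effect. Compound 1 `CCCCCCCCCO[C@@H]1[C@@H](N)[C@@H](OCC(O)CNCCO)O[C@H](CN)[C@H]1OCCCCCCCCC` gives 10.1%. Compound 2 `CCCCCCCCCO[C@@H]1[C@@H](N)[C@@H](OCC(O)CNCCCN)O[C@H](CN)[C@H]1OCCCCCCCCC` gives 71.6%. Compound 3 `C=CCO[C@H]1O[C@H](CN)[C@@H](OCCCCCCCCC)[C@H](OCCCCCCCCC)[C@H]1N` gives 6.6%. On these numbers compound 3 and compound 1 lie within the usual scatter of one another, as the step of a number 3.5 percentage points lower from compound 1 to compound 3 (within the scatter) shows, while compound 2 stands well apart from both: a number 61.5 percentage points higher from compound 1 to compound 2 (beyond the scatter) and a number 65 percentage points lower from compound 2 to compound 3 (beyond the scatter).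

Compound 4 `CCCCCCCCCO[C@@H]1[C@@H](N)[C@@H](OCC(O)CO)O[C@H](CN)[C@H]1OCCCCCCCCC` has not yet been measured in this assay. It differs from compound 3 by 1,2-dihydroxyethyl in place of vinyl on a saturated chain carbon bound to an oxygen on a saturated carbon. Among the compounds with values here, the step that bears on this is the one from compound 1 to compound 3, which exchanged a longer hydroxy-bearing chain for the vinyl and changed nothing beyond the scatter. The large steps involving compound 2 concern an aminomethyl-terminated chain, which compound 4 does not carry; the group entering in compound 4 brings hydroxy groups only, as in compound 1.

Compound 4 is therefore expected to sit close to compound 3, with a step of a number 3.4 percentage points higher from compound 3 to compound 4 (within the scatter), which is within the scatter. The estimate for compound 4 in this assay is 10%, with a range from 3% to 25%.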

Compound 4, a percentage reported as activity, at one concentration (the size of the read-out at that concentration, not a potency): 8.8%
The estimate for compound 4 lay 1.2 percentage points above the measured number; measured number inside the range.
By their numbers in this assay, from the lowest: compounds 3, 4 and 1 (each within the scatter of the next); then compound 2.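

In this assay the change from allyloxy to 2,3-dihydroxypropoxy at this position leaves the read-out within the scatter (a number 2.2 percentage points higher from compound 3 to compound 4 (within the scatter)), so the hydroxy groups entering here do not set compound 4 apart from compound 3. On the same chain, hydroxy in place of (2-hydroxyethyl)amino also stays within the scatter (a number 1.3 percentage points lower from compound 1 to compound 4 (within the scatter)), whereas hydroxy in place of (3-aminopropyl)amino gives a large step (a number 62.8 percentage points lower from compound 2 to compound 4 (beyond the scatter)), so among these compounds a chain nitrogen alone, as in compound 1, does not go with the high number of compound 2, and only the (3-aminopropyl)amino group stands apart. The data at hand give no reason for any of these steps.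

Still open, on these data alone, is whether the high number depends on the terminal amine of the (3-aminopropyl)amino group or on its chain length, which a 2-aminoethylamino group or a longer diamine chain would test. Also open is how a carboxylic acid or a guanidine at the end of this chain would read, since every end group shown carries only hydroxy or amine functions or the allyl double bond.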